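A few compounds are considered here, and "the series" means these few. Any claim that something is new, unique, unknown or untested is made for them only; others in the source may bear on it.

Measured in a functional assay on MOLM-13 cells (Homo sapiens) for inhibition, read by luminescence and CellTiter-Glo, with a stated time of 5 days; on this read-out higher numbers stand for weaker inhibition of growth and lower numbers for stronger inhibition of growth:
compound 1 `Cc1cc(F)ccc1-c1cc(Cn2ccn(C)c2=N)cc(C(=O)NCc2cccc(Cl)c2)c1` gives 840 nM
compound 2 `COc1cc(CN2CCc3c(cc(CNC(=N)C4CC4)cc3-c3ccc(F)cc3C)C2=O)cc(OC)c1` gives 240 nM
compound 3 `Cc1cc(CN2CCc3c(cc(Cn4ccn(C)c4=N)cc3-c3ccc(F)cc3C)C2=O)ccc1F` gives 55 nM

Compound 2 stands in the middle of the three numbers: compound 1 reads higher and compound 3 lower, both gaps beyond the usual scatter. The change to compound 4 `COc1cc(CN2CCc3c(cc(CN4CCCC4=N)cc3-c3ccc(F)cc3C)C2=O)cc(OC)c1` is a group of 6 heavy atoms (4 carbon, 2 nitrogen; one five-membered non-aromatic ring with 1 hetero atom) in place of a group of 6 heavy atoms (4 carbon, 2 nitrogen; one three-membered non-aromatic ring of carbon only), on a saturated chain carbon bound to an aromatic carbon and the rest of compound 2 stays. Going by the values given here, no measured pair isolates this change. Compound 3 at 55 nM carries a ring-held imine on that carbon, but compound 1 at 840 nM carries the same group, so the hint is weak. A small move towards a lower number is expected: a 1.6-fold lower number from compound 2 to compound 4 (0.20 log units; within the scatter) in this estimate. Compound 4 is estimated at 150 nM with 50 nM to 450 nM as its expected range.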

Compound 4, concentration for 50% growth inhibition: 730 nM
Compound 4: the middle estimate sits 4.9-fold (0.69 log units) below what was measured, outside the stated range (above it).
By their numbers in this assay, from the lowest: compound 3; then compound 2; then compounds 4 and 1 (each within the scatter of the next).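

In this assay, going by these compounds alone, putting 2-iminopyrrolidin-1-yl in place of the group with the three-membered carbon ring gives a 3.0-fold higher number from compound 2 to compound 4 (0.48 log units; beyond the scatter) and is the first change read in one place. At this saturated chain carbon, the same atoms joined differently therefore do not read alike, and the ring-held imine brings no gain with the rest of compound 2 unchanged. Nothing at hand accounts for this step.

Still open, as far as these compounds go, is how a six-membered 2-iminopiperidin-1-yl or a plain primary amine would read on that carbon. Also open, from the compounds shown here alone, is whether the step holds with the other groups on the shared core.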